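Heteroaryl in place of dichlorophenyl on the amide nitrogen

The compounds below may be only part of what the source reports. "The series", "measured", "known", "first", "only" and "open" are said of these compounds alone.

Measured in a functional assay on DU-145 cells (Homo sapiens) for antiproliferative activity, read by sulforhodamine B assay, with a stated time of 3 days; on this read-out lower numbers stand for stronger inhibition of growth and higher numbers for weaker inhibition of growth:
compound 1 `COc1ccc(N2CCN(C)CC2)cc1Nc1ncc(F)c(Nc2ccc(F)cc2)n1`: 910 nM
compound 2 `O=C(Nc1cc(Cl)cc(Cl)c1)c1cccc(Nc2ncc(F)c(Nc3ccc(F)cc3)n2)c1`: 17500 nM
compound 3 `O=C(Nc1cccc(Nc2ncc(F)c(Nc3ccc(F)cc3)n2)c1)c1ccncc1`: 4330 nM

Compound 2 gives the highest number of the three; compound 3 stands nearest to it with a lower number, compound 1 furthest, and both gaps lie beyond the scatter. Compound 4 `O=C(Nc1nccs1)c1cccc(Nc2ncc(F)c(Nc3ccc(F)cc3)n2)c1` is not yet measured. It differs from compound 2 in that (1,3-thiazol-2-yl in place of 3,5-dichlorophenyl on an amide-type nitrogen). For the measured compounds named here, the one measured step that bears on this is a 4.0-fold lower number from compound 2 to compound 3 (0.61 log units; beyond the scatter), which also removes the 3,5-dichlorophenyl group from the amide side of compound 2, though the two changes are not identical. A modest step to a lower number in this assay is therefore expected, a 2.9-fold lower number from compound 2 to compound 4 (0.46 log units; beyond the scatter). Compound 4 is estimated at 6000 nM, with a range from 2500 nM to 14000 nM.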

Compound 4, concentration for 50% growth inhibition: > 10000 nM
Compound 4: no number, only a limit; the forecaster's own chance of this, stated with the estimate: 5%; middle value at least 1.6-fold (0.22 log units) from the limit.
By their numbers in this assay, from the lowest: compound 1; then compound 3; then compound 2.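

Compound 4 gives only a limit, not a number: the limit of > 10000 nM in this assay, at which 1 of the 4 values shown sits.

The step from compound 2 therefore cannot be read, so the 1,3-thiazol-2-yl group cannot be ranked against 3,5-dichlorophenyl on this amide-type nitrogen. The readable step, an at least 2.3-fold higher number from compound 3 to compound 4 (0.36 log units; beyond the scatter), shows that the lower number of compound 3 does not extend to this heteroaryl amide.

Still open, as far as these compounds go, is whether the ring or the amide direction separates compound 3 from compound 4. From the compounds shown here alone, how a morpholine or a carboxylic acid on the amide side would read also remains open.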